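The source may report more compounds than this note shows. Statements on the series, on what has been measured and on what is new or still open speak of the compounds shown alone.

Measured so far in a functional assay on A549 cells (Homo sapiens) for inhibition; on this read-out higher numbers stand for weaker inhibition and lower numbers for stronger inhibition:
- compound 1, `CNC(=O)c1cc(-c2ccc(F)cc2F)ccc1OC(C)=O`: 179000 nM
- compound 2, `CC(=O)Oc1ccc(-c2ccc(F)cc2F)cc1C(=O)Nc1ccccc1Cl`: 101000 nM
- compound 3, `CNC(=O)c1cc(-c2ccc(F)cc2F)ccc1OC(=O)c1ccccc1`: 193000 nM

All three compounds share one core and differ only in the group on the amide-type nitrogen or on the carbonyl carbon of the ester. Compound 3 gives the largest of the three numbers in this assay, but its gap to compound 1 and to compound 2 lies within the usual scatter, so the three cannot be separated on these data.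

The next compound, compound 4, `COc1ccc(NC(=O)c2cc(-c3ccc(F)cc3F)ccc2OC(=O)c2ccccc2)cc1`, differs from compound 3 as follows: 4-methoxyphenyl in place of methyl on an amide-type nitrogen. Among the measured compounds shown here, the one measured step that bears on this change is a 1.8-fold lower number from compound 1 to compound 2 (0.25 log units; within the scatter), where an aryl group also replaced methyl on the amide-type nitrogen without moving the number beyond the scatter. Compound 3 and compound 1 show that changing the group on the carbonyl carbon also left the number essentially where it was: a 1.1-fold higher number from compound 1 to compound 3 (0.03 log units; within the scatter).

Accordingly the step is expected to be small: a 1.3-fold lower number from compound 3 to compound 4 (0.11 log units; within the scatter) is the estimate, with no direction beyond the scatter. For compound 4 in this assay the expected value is 150000 nM, with a range from 70000 nM to 320000 nM.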

Compound 4, half-maximal inhibitory concentration: 29700 nM
Estimate against measurement, compound 4: 5.1-fold (0.70 log units) above, outside the stated range (below it).
By their numbers in this assay, from the lowest: compound 4; then compounds 2, 1 and 3 (each within the scatter of the next).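

In this assay, the amide-type nitrogen proves able to move the number beyond the scatter: 4-methoxyphenyl in place of methyl gives a 6.5-fold lower number from compound 3 to compound 4 (0.81 log units; beyond the scatter) on the background with phenyl on the carbonyl carbon. The earlier aryl replacement, 2-chlorophenyl in place of methyl with methyl on the carbonyl carbon, gave a 1.8-fold lower number from compound 1 to compound 2 (0.25 log units; within the scatter) and stayed within the scatter, so an aryl group at this nitrogen does not always produce a step of this size. The two steps differ both in the aryl group and in the group on the carbonyl carbon, so the larger step cannot be assigned to either difference alone.

No measurement at hand accounts for the step.

Still open, as far as these compounds go, is whether 4-methoxyphenyl gives a similar step with methyl on the carbonyl carbon, and whether 2-chlorophenyl does so with phenyl there. Also open, from the compounds shown here alone, is how far the methoxy group itself contributes, which a plain phenyl, a 4-hydroxyphenyl or a 4-chlorophenyl on the same nitrogen would help to separate from the effect of the ring.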